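Sulfonyl substituent trimming in an aryl-alkyne acetic acid series

A few compounds are considered here, and "the series" means these few. Any claim that something is new, unique, unknown or untested is made for them only; others in the source may bear on it.

The series shares an aryl-alkyne acetic acid core carrying a sulfonyl group on the second ring. Compound 1 `COCCN(C)S(=O)(=O)c1ccc(C)c(C#Cc2cc(Cl)ccc2OCC(=O)O)c1` bears a methoxyethyl(methyl)aminosulfonyl group and in a functional assay on cells for antagonist activity at prostaglandin D2 receptor 2 (Homo sapiens), read by flow cytometry, with a stated time of 10 min (a lower number here means a stronger inhibitor, a higher number a weaker inhibitor), compound 1 gives 77 nM. Compound 2 `CC(C)S(=O)(=O)c1ccc(Cl)c(C#Cc2cc(Cl)ccc2OCC(=O)O)c1` carries an isopropylsulfonyl group and in this assay compound 2 gives 67 nM. On the two numbers available, compound 2 and compound 1 sit within the usual scatter of each other, so neither can be set apart from the other.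

Compound 3 `CS(=O)(=O)c1ccc(Cl)c(C#Cc2cc(Cl)ccc2OCC(=O)O)c1` is the next member. It differs from compound 2 by methyl in place of isopropyl on a sulfonyl sulfur. Among the compounds with values here, no measured pair shows such a change, so no step is known. The expectation is a modest shift from compound 2 to compound 3 in this assay, a 1.3-fold higher number from compound 2 to compound 3 (0.13 log units; within the scatter), of a size that may not exceed the scatter. For compound 3 the estimate in this assay is 90 nM, with a range from 30 nM to 300 nM.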

Compound 3, half-maximal inhibitory concentration: 26 nM
For compound 3 the middle estimate is 3.5-fold (0.54 log units) above the measured one; measured number below the stated range.
By their numbers in this assay, from the lowest: compound 3; then compounds 2 and 1 (each within the scatter of the next).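

Going from isopropylsulfonyl to methylsulfonyl gives a 2.6-fold lower number from compound 2 to compound 3 (0.41 log units; beyond the scatter) in this assay, so the group on this sulfonyl sulfur does affect the read-out. Compounds 1 and 2 could not show this, as they differ in more than one place; here, only the sulfur substituent changes, from three carbons to one, with the rest of the structure held constant. Nothing at hand accounts for the step, and it remains an observation on a single matched pair.

As far as these compounds go, two alkyl groups define no trend at this place, so it remains open whether ethyl would fall between methyl and isopropyl. Also open, from the compounds shown here alone, is how a cyclopropyl ring or a dimethylamino group on the same sulfur would read with the rest of compound 3 unchanged.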